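Adding a 4-hydroxy-3-methoxybenzyl group to a long-chain amide

The source may hold more compounds than are shown below. What is called first, only, known or untested is meant among the compounds shown, and "the series" means these compounds.

Compound 1 `CCCCCCCCCCCCCCCCCC(=O)NCc1ccc(O)c(OC)c1` — in an assay on HEK293 cells for antagonist activity at transient receptor potential cation channel subfamily V member 2 (Rattus norvegicus), read by fluorescence and calcium flux, with a stated time of 5 min (a higher number here means a weaker inhibitor, a lower number a stronger inhibitor), compound 1 gives > 10000 nM, a limit of the assay rather than a number.
Compound 2 `CCCCCCCCCCCCCCCC(=O)NCc1ccc(O)c(OC)c1` — in this assay compound 2 gives > 10000 nM, again a limit.
Compound 3 `CCCCCCCCCCCCCCCCCCCC(N)=O` — in this assay compound 3 gives > 10000 nM, also a limit.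

Compound 3 therefore stands only at a limit, as do all three values shown (the limit of > 10000 nM in this assay, at which 3 of the 3 values shown sit). Going by the values given here, the single measured step, a step that the two limits leave unreadable from compound 1 to compound 2, cannot be read, both of its ends being limits, and it concerns only the length of the saturated chain.

Compound 4 `CCCCCCCCCCCCCCCCCCCC(=O)NCc1ccc(O)c(OC)c1` differs from compound 3 by 4-hydroxy-3-methoxybenzyl in place of hydrogen on an amide-type nitrogen. Among the compounds with values here, no measured step covers this kind of change. What is known is that compound 1 and compound 2 already carry the same 4-hydroxy-3-methoxybenzyl group on shorter chains and both sit at the limit. On that basis compound 4 is expected to stay at the limit as well in this assay, so the step that the limit leaves unreadable from compound 3 to compound 4 is expected to be none beyond the scatter. The estimate for compound 4 is 20000 nM, with a range from 8000 nM to 100000 nM.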

Compound 4, half-maximal inhibitory concentration: > 10000 nM
Compound 4: a limit, no number; the forecaster's own chance of this, stated with the estimate: 85%; the middle value is on the limit's open side.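

Compound 4 also sits at a limit, so none of the steps linking it to compound 1, compound 2 and compound 3 can be read: the limit of > 10000 nM in this assay, at which 4 of the 4 values shown sit.

The compounds shown leave open whether the 4-hydroxy-3-methoxybenzyl group or the length of the saturated chain changes inhibition at all.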